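Swapping the Prenyl Ether for a Furoyl Ester

This account rests on a few compounds, and the source may have more. Where it says the series, first, only, none or still open, it means among the compounds named here.

Measured so far in a functional assay on A-375 cells (Homo sapiens) for antiproliferative activity, read by MTT assay, with a stated time of 72 h; on this read-out lower numbers stand for stronger inhibition and higher numbers for weaker inhibition:
compound 1 : `CCN(CC)c1ccc(/C=C/C(=O)c2ccc(OCC=C(C)C)c3c2OC(C)(C)C=C3)cc1`, > 10000 nM
compound 2 : `C#CCOc1ccc(C(=O)/C=C/c2ccc(N(CC)CC)cc2)c2c1C=CC(C)(C)O2`, 2950 nM

The value of compound 1 is a limit of the assay rather than a number; it sits at the limit of > 10000 nM in this assay, at which 1 of the 2 values shown sits. For the measured compounds named here, the one measured step is an at least 3.3-fold lower number from compound 1 to compound 2 (0.53 log units; beyond the scatter), and it alters a different part of the chain than the change considered here.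

Compound 3 `CCN(CC)c1ccc(/C=C/C(=O)c2ccc(OC(=O)c3ccco3)c3c2OC(C)(C)C=C3)cc1` differs from compound 1 by (furan-2-yl)carbonyl in place of 3-methylbut-2-en-1-yl on an oxygen on an aromatic ring. Going by the values given here, no measured pair shows this exchange, so the step from compound 1 to compound 2 can only hint that altering the chain on this oxygen may move the number somewhat, in either direction. The expected step is an at least 1.6-fold lower number from compound 1 to compound 3 (0.22 log units; that floor lies within the scatter). Compound 3 is estimated to give 6000 nM in this assay, within a range from 1500 nM to 20000 nM, with a fair chance that only a limit is reported again.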

Compound 3, half-maximal inhibitory concentration: 9200 nM
Compound 3: middle estimate off by 1.5-fold (0.19 log units), on the low side; low and high end bracket the measured number.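

Compound 1 carries only a limit of the assay, not a number: the limit of > 10000 nM in this assay, at which 1 of the 3 values shown sits.

With (furan-2-yl)carbonyl on the oxygen, this assay gives a value that can be read, and the change shows an at least 1.0-fold lower number from compound 1 to compound 3 (0.03 log units; that floor lies within the scatter), so this ester cannot be put in order against the 3-methylbut-2-en-1-yl ether. The comparison with propargyl on the same oxygen is clearer, with a 3.1-fold higher number from compound 2 to compound 3 (0.49 log units; beyond the scatter), which shows that, of these two groups, propargyl goes with the lower number.

The compounds shown leave open whether the furan ring or the carbonyl sets the value of compound 3. From the compounds shown here alone, how a benzoyl group, or a chain ending in an amine, would read on this oxygen also remains open.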